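Moving the methyl around the benzyl ring

The compounds below may be only part of what the source reports. "The series", "measured", "known", "first", "only" and "open" are said of these compounds alone.

Of the compounds shown here, two of a shared core have been measured in an assay for inhibition of Amine oxidase [flavin-containing] B (Rattus norvegicus); on this read-out higher numbers stand for weaker inhibition and lower numbers for stronger inhibition. Compound 1 `COc1cccc(COc2ccc(-c3nn(CCC#N)c(=S)o3)cc2)c1` gives 100 nM in this assay. Compound 2 `Cc1cccc(COc2ccc(-c3nn(CCC#N)c(=S)o3)cc2)c1` gives 66 nM in this assay. For the measured compounds named here, compound 2 stands alongside compound 1 rather than apart from it: the one step so far, a 1.5-fold lower number from compound 1 to compound 2 (0.18 log units; within the scatter), lies within the scatter, so nothing separates the two on these numbers.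

Compound 3 `Cc1ccc(COc2ccc(-c3nn(CCC#N)c(=S)o3)cc2)cc1` has not yet been measured. It differs from compound 2 by 4-methylphenyl in place of 3-methylphenyl on a saturated chain carbon bound to an oxygen on an aromatic ring; the two have the same atoms, joined differently. Going by the values given here, no measured step bears directly on this change, since the only step in hand exchanges methoxy for methyl at one position and does not move a group from one position to another. That step was within the scatter, and nothing else here points toward a change in either direction. Compound 3 is therefore expected to give about 70 nM in this assay, with an estimated range from 25 nM to 200 nM. The step from compound 2 to compound 3 is expected to be a 1.1-fold higher number from compound 2 to compound 3 (0.03 log units; within the scatter), which would be within the scatter.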

Compound 3, half-maximal inhibitory concentration: 400 nM
Estimate against measurement, compound 3: 5.7-fold (0.76 log units) below; measured number outside the range, above it.
By their numbers in this assay, from the lowest: compounds 2 and 1 (each within the scatter of the next); then compound 3.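

In this assay, the place of the methyl on the ring matters in a way the earlier pair could not show: with the atoms unchanged, the shift from 3-methylbenzyl to 4-methylbenzyl gives a 6.1-fold higher number from compound 2 to compound 3 (0.78 log units; beyond the scatter), whereas exchanging methoxy for methyl at one position had stayed within the scatter. The comparison with the methoxy compound points the same way, with 4-methylphenyl in place of 3-methoxyphenyl giving a 4.0-fold higher number from compound 1 to compound 3 (0.60 log units; beyond the scatter), so among these three compounds the two groups named with a 3 give the lower numbers and none goes against that. Nothing at hand explains why the two placements differ.

As far as these compounds go, it remains open whether the same shift would raise the number as much with a methoxy, a chlorine or an amine in place of the methyl, since only the methyl has been seen in both places. From the compounds shown here alone, it is also open whether the gap would hold if a longer chain replaced the one carrying the nitrile on the shared core.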